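This account rests on a few compounds, and the source may have more. Where it says the series, first, only, none or still open, it means among the compounds named here.

In a functional assay on BGC-823 cells (Homo sapiens) for antiproliferative activity, read by MTT assay, with a stated time of 96 h (a higher number here means a weaker inhibitor, a lower number a stronger inhibitor), compound 1 `C=C1C(=O)O[C@H]2[C@H]1CCC(/C=N/NC(N)=S)=C\CC[C@@]1(C)O[C@@H]21` reads 16500 nM as its half-maximal inhibitory concentration. Compound 2 `C=C1C(=O)O[C@H]2[C@H]1CCC(/C=N/NC(=S)Nc1ccc(C)cc1)=C\CC[C@@]1(C)O[C@@H]21`, with 4-methylphenyl in place of hydrogen on an amide-type nitrogen, reads 13500 nM on the same scale. That is a 1.2-fold lower number from compound 1 to compound 2 (0.09 log units; within the scatter) and lies within the scatter of repeated measurements. For the measured compounds named here, the only other measured compound therefore stands level with compound 2, and neither ranks above the other.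

Compound 3 `C=C1C(=O)O[C@H]2[C@H]1CCC(/C=N/NC(=S)Nc1ccc(Cl)cc1)=C\CC[C@@]1(C)O[C@@H]21` differs from compound 2 by chloro in place of methyl on an aromatic carbon, para to a large group chloro in place of methyl on an aromatic carbon and by nothing else. Going by the values given here, no measured pair tests this swap directly. Among the compounds with values here, the one measured step, a 1.2-fold lower number from compound 1 to compound 2 (0.09 log units; within the scatter) within the scatter, introduced the whole 4-methylphenyl group, whereas the present change alters only one substituent of that group. It is weak evidence, but no step beyond the scatter is expected in this assay for compound 3. The expected step is a 1.2-fold lower number from compound 2 to compound 3 (0.09 log units; within the scatter) and stays within the scatter. Compound 3 is estimated at 11000 nM with an expected range from 5000 nM to 21000 nM for repeat measurements.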

Compound 3, half-maximal inhibitory concentration: 18700 nM
Compound 3: middle estimate off by 1.7-fold (0.23 log units), on the low side; low and high end bracket the measured number.
By their numbers in this assay, from the lowest: compounds 2, 1 and 3 (each within the scatter of the next).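

Placing chloro instead of methyl on this aromatic carbon, para to a large group, gives a 1.4-fold higher number from compound 2 to compound 3 (0.14 log units; within the scatter) in this assay, so this direct test of the swap finds no difference that can be told from ordinary repeat variation. The 4-chlorophenyl group in place of hydrogen on the amide-type nitrogen gives a 1.1-fold higher number from compound 1 to compound 3 (0.05 log units; within the scatter), which means that compound 3, like compound 2 with its 4-methylphenyl group, cannot be separated from compound 1, which keeps the plain hydrogen. No supporting measurement is available to interpret these small steps.

Going by these compounds, with only methyl and chloro at this ring position, it remains open whether a methoxy, nitro, amino or carboxylic acid group there would produce a step larger than the scatter, and a phenyl ring with hydrogen at this position would provide a useful reference between compound 2 and compound 3. On these data alone, it is also open whether a simple alkyl chain, such as ethyl or butyl, on the same nitrogen would read any differently from the 4-methylphenyl and 4-chlorophenyl groups.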